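Compound 2 and its propyl chain analogue, compound 4

A few compounds are considered here, and "the series" means these few. Any claim that something is new, unique, unknown or untested is made for them only; others in the source may bear on it.

Measured in a functional assay on SH-SY5Y cells (Homo sapiens) for cytotoxicity, read by MTT assay, with a stated time of 72 h; on this read-out higher numbers stand for weaker inhibition and lower numbers for stronger inhibition:
- compound 1 `O=C1c2c[n+]([O-])c3ccccc3c2C(=O)c2c1c1ccccc1n2Cc1cn([C@@H]2C[C@H](O)[C@@H](CO)O2)nn1`: 150 nM
- compound 2 `CN1CCN(CCCCn2c3c(c4ccccc42)C(=O)c2c[n+]([O-])c4ccccc4c2C3=O)CC1`: 100 nM
- compound 3 `CC1(C)OC[C@H](Cn2cc(Cn3c4c(c5ccccc53)C(=O)c3c[n+]([O-])c5ccccc5c3C4=O)nn2)O1`: 820 nM

In this assay compound 2 gives 100 nM and compound 1 gives 150 nM, two values within the usual scatter of each other. Compound 3 gives 820 nM. The gap from this value to each of the other two is larger than the usual scatter.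

The next structure is compound 4 `CN1CCN(CCCn2c3c(c4ccccc42)C(=O)c2c[n+]([O-])c4ccccc4c2C3=O)CC1`, which has not yet been measured. The change from compound 2 is 4-methylpiperazin-1-yl in place of (4-methylpiperazin-1-yl)methyl on a saturated chain carbon, three bonds along the chain from an aromatic nitrogen. Cut one bond further out, it reads 4-(4-methylpiperazin-1-yl)butyl to 3-(4-methylpiperazin-1-yl)propyl.

Within the data shown here, only one measured step bears on this, and only loosely: a 5.5-fold higher number from compound 1 to compound 3 (0.74 log units; beyond the scatter). It shows that a change in a side chain can move the number beyond the scatter, but it replaces one end group with another and does not alter a chain length. Among the measured compounds shown here, no measured pair varies the length of the chain, so no step beyond the scatter is expected in this assay, although the range is kept wide. The expected step is a 1.1-fold higher number from compound 2 to compound 4 (0.04 log units; within the scatter). Compound 4 is estimated at 110 nM, with an expected range of 45 nM to 280 nM.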

Compound 4, half-maximal inhibitory concentration: 560 nM
Compound 4: the middle estimate sits 5.1-fold (0.71 log units) below what was measured; the measured number lies above the stated range.
By their numbers in this assay, from the lowest: compounds 2 and 1 (each within the scatter of the next); then compounds 4 and 3 (each within the scatter of the next).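

In this assay, shortening 4-(4-methylpiperazin-1-yl)butyl to 3-(4-methylpiperazin-1-yl)propyl gives a 5.6-fold higher number from compound 2 to compound 4 (0.75 log units; beyond the scatter), which shows that chain length at this position can move the number beyond the scatter while the end group stays the same. The earlier step, a 5.5-fold higher number from compound 1 to compound 3 (0.74 log units; beyond the scatter), exchanged one end group for another, so it could not separate the chain from the group it carries; here the 4-methylpiperazine end is common to both compounds and the difference lies in the chain alone. Nothing available here bears on what lies behind this step.

With only the butyl and propyl chains shown, these two points fix no trend, and it remains open whether an ethyl chain or a longer pentyl chain would carry the number further in the same direction or reverse it. On these data alone, it also remains open whether another amine at the chain end, such as morpholine or dimethylamine, would respond to the same shortening as the 4-methylpiperazine does.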